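Aryl substituent changes on the shared core: cytotoxicity notes

This account rests on a few compounds, and the source may have more. Where it says the series, first, only, none or still open, it means among the compounds named here.

Measured so far:
Compound 1 `O=C(NCCCCC(c1ccc(F)cc1)c1ccc(F)cc1)Nc1ccc(I)cc1`; in a functional assay on MDA-MB-231 cells (Homo sapiens) for cytotoxicity, read by MTT assay, with a stated time of 48 h (a lower number here means a stronger inhibitor, a higher number a weaker inhibitor), compound 1 gives 11800 nM.
Compound 2 `O=C(NCCCCC(c1ccc(F)cc1)c1ccc(F)cc1)Nc1ccc([N+](=O)[O-])cc1`; compound 2 gives 6470 nM.
Compound 3 `O=C(NCCCCC(c1ccc(F)cc1)c1ccc(F)cc1)Nc1ccc(Cl)c(C(F)(F)F)c1`; compound 3 gives 3150 nM.

Compound 2 stands second highest of the three numbers: its nearest neighbour is compound 1, a 1.8-fold lower number from compound 1 to compound 2 (0.26 log units; within the scatter), and its furthest is compound 3, a 2.1-fold lower number from compound 2 to compound 3 (0.31 log units; beyond the scatter). Going by the values given here, the only step beyond the scatter in the set is from compound 1, a 3.7-fold lower number from compound 1 to compound 3 (0.57 log units; beyond the scatter).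

Compound 4 `Nc1cc(NC(=O)NCCCCC(c2ccc(F)cc2)c2ccc(F)cc2)ccc1Cl` is not yet measured. It differs from compound 2 as follows: 3-amino-4-chlorophenyl in place of 4-nitrophenyl on an amide-type nitrogen.

Among the compounds with values here, the step that bears most directly on this change is the one from compound 2 to compound 3, where a different 4-chloro-substituted aryl replaced the 4-nitrophenyl and gave a modest gain. Within the data shown here, compound 4 also carries chloro on the entering ring, but an amino rather than a trifluoromethyl, and no measured compound covers that group. The step from compound 1 to compound 2 showed that exchanging one para group for another can fall within the scatter. A modest gain at most, or no step beyond the scatter, is therefore expected: a 1.3-fold lower number from compound 2 to compound 4 (0.11 log units; within the scatter). Compound 4 is estimated at 5000 nM, with a range from 2000 nM to 12500 nM.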

Compound 4, half-maximal inhibitory concentration: 9240 nM
Beside the measured number, compound 4's estimate is 1.8-fold (0.27 log units) below it; the measured number falls inside the stated range.
By their numbers in this assay, from the lowest: compound 3; then compounds 2, 4 and 1 (each within the scatter of the next).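

In this assay, amino in place of trifluoromethyl on an aromatic carbon gives a 2.9-fold higher number from compound 3 to compound 4 (0.47 log units; beyond the scatter), the first change shown that leaves the chloro on the ring and alters only the group that accompanies it, and this step lies beyond the scatter. The other two steps, a 1.4-fold higher number from compound 2 to compound 4 (0.15 log units; within the scatter) and a 1.3-fold lower number from compound 1 to compound 4 (0.11 log units; within the scatter), stay within the scatter, so in this small set a chloro on the ring does not by itself go with the lower number of compound 3: compound 4 carries a chloro too, yet it sits with compound 1 and compound 2. Nothing in the data given speaks to the reason for the gap between the amino and trifluoromethyl compounds.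

From the compounds shown here alone, it remains open whether the lower number of compound 3 follows from the trifluoromethyl alone or from its pairing with chloro, a question that a 3-(trifluoromethyl)phenyl and a 4-chlorophenyl urea on the same core would address. Also open, going by these compounds, is how a methyl, a nitrile or a methoxy would read in the place held by the amino, and whether any of these steps would hold on a shorter chain.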